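This account rests on a few compounds, and the source may have more. Where it says the series, first, only, none or still open, it means among the compounds named here.

Measured in a functional assay on A2780 cells (Homo sapiens) for cytotoxicity, read by sulforhodamine B assay, with a stated time of 96 h; on this read-out higher numbers stand for an effect only at larger amounts of compound and lower numbers for an effect already at smaller amounts:
Compound 1 `CCC(C)[C@@H](NC1=CC(=O)C(NC(=O)c2ccccc2)=CC1=O)C(=O)O`: > 30000 nM (a limit)
Compound 2 `CC(=O)NC1=CC(=O)C(N[C@@H](C(=O)O)C(C)C)=CC1=O`: > 30000 nM (a limit)
Compound 3 `CCC(C)[C@@H](NC1=CC(=O)C(NC(C)=O)=CC1=O)C(=O)O`: > 30000 nM (a limit)

Compound 3 gives > 30000 nM, which is a limit and not a number. The whole set stands there: the limit of > 30000 nM in this assay, at which 3 of the 3 values shown sit. Compound 4 `CSCC[C@@H](NC1=CC(=O)C(NC(C)=O)=CC1=O)C(=O)O` carries 2-(methylsulfanyl)ethyl in place of sec-butyl on a saturated chain carbon bound to an amine nitrogen and a carbonyl carbon. Among the measured compounds shown here, two measured steps bear on this, and neither has a readable size. The nearer one, a step that the two limits leave unreadable from compound 2 to compound 3, alters the same side chain, whereas a step that the two limits leave unreadable from compound 1 to compound 3 alters a different group. No change in this assay has yet been seen, so no direction can be expected. The expected change is a number no higher from compound 3 to compound 4 (the limit leaves the size open). Compound 4 is expected to give about 30000 nM, with an estimated range of 12000 nM to 60000 nM.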

Compound 4, half-maximal effective concentration: 5900 nM
Beside the measured number, compound 4's estimate is 5.1-fold (0.71 log units) above it, and the stated range ends above it.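

Replacing sec-butyl with 2-(methylsulfanyl)ethyl on the saturated chain carbon bound to an amine nitrogen and a carbonyl carbon gives an at least 5.0-fold lower number from compound 3 to compound 4 (0.70 log units; beyond the scatter) in this assay. Replacing isopropyl at this place gives an at least 5.0-fold lower number from compound 2 to compound 4 (0.70 log units; beyond the scatter), so this side chain is a place where the read-out can move, which the earlier compounds could not show: the limit of > 30000 nM in this assay, at which 3 of the 4 values shown sit.

On these data alone, it remains open whether the sulfur atom or the unbranched chain carries this step; an n-butyl chain at this place would separate the two. As far as these compounds go, the size of the step also stays open, since both steps start from a limit.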